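The compounds below may be only part of what the source reports. "The series", "measured", "known", "first", "only" and "open" are said of these compounds alone.

The measured compounds:

compound 1, `COc1ccc(-c2cc(/C=C/C(=O)c3ccc(N)cc3)[nH]n2)cc1`, -93%
compound 2, `COc1ccc(-c2cc(/C=C/C(=O)c3ccc(N)cc3)[nH]n2)cc1OC`, -86%
compound 3, `COc1cc(C(=O)/C=C/c2cc(-c3cc(OC)c(OC)c(OC)c3)n[nH]2)cc(OC)c1OC`, -97%

All three were tested in a functional assay on UACC-62 cells (Homo sapiens) for cytotoxicity, read by sulforhodamine B assay, with a stated time of 48 h, tested at 100 uM; on this read-out higher numbers stand for a weaker effect at the one concentration tested and lower numbers for a stronger effect. Compound 2 and compound 1 differ in one place, (hydrogen in place of methoxy on an aromatic carbon), and the step of a number 7 percentage points lower from compound 2 to compound 1 (within the scatter). Compound 3 has the lowest number of the three; against compound 1 it lies within the scatter, while against compound 2 the gap between the two values runs beyond it. The difference between the core of compound 3 and the core of compound 2 is not broken down here.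

Compound 4, `COc1ccc(-c2cc(/C=C/C(=O)c3cc(OC)c(OC)c(OC)c3)[nH]n2)cc1OC`, is not yet measured. It differs from compound 3 by hydrogen in place of methoxy on an aromatic carbon. Among the measured compounds shown here, this is the same kind of change as the one from compound 2 to compound 1, but the surroundings differ: in compound 3 the carbon is also meta to a methoxy group. Because the earlier step was a number 7 percentage points lower from compound 2 to compound 1 (within the scatter), a step of similar size is expected from compound 3 to compound 4, a number 6 percentage points higher from compound 3 to compound 4 (within the scatter). Compound 4 is therefore expected to give about -91% in this assay, between -100% and -79%.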

Compound 4, a percentage reported as activity, at one concentration (the size of the read-out at that concentration, not a potency): -80%
The estimate for compound 4 lay 11 percentage points below the measured number; measured number inside the range.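

In this assay, putting hydrogen in place of a methoxy group on an aromatic carbon gave a number 17 percentage points higher from compound 3 to compound 4 (beyond the scatter). Set beside the earlier case, the same change did not carry over from one core to the other with the same size: the same change on two cores in this assay, a number 7 percentage points lower (within the scatter) from compound 2 to compound 1 and a number 17 percentage points higher (beyond the scatter) from compound 3 to compound 4, 24 percentage points apart, beyond the scatter of two such steps. This shows that, for these two pairs, the step measured on the core of compound 2 was a poor guide to the step on the core of compound 3, but two pairs cannot show which feature of the cores sets the gap or how the change would behave on a further core.

As far as these compounds go, whether a hydroxyl group, a fluorine atom or a carboxylic acid in place of the methoxy group would move the number in this assay stays open. Also open, from the compounds shown here alone, is whether these compounds would show a stronger or weaker effect at other concentrations or in other cell lines: the read-out gives the size of the effect at a single concentration in a single cell line.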